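The source may hold more compounds than are shown below. What is called first, only, known or untested is meant among the compounds shown, and "the series" means these compounds.

Measured in an ADME assay on MT4 cells (Homo sapiens) for cytotoxicity, read by MTT assay, with a stated time of 96 h; on this read-out lower numbers stand for higher toxicity in this test and higher numbers for lower toxicity in this test:
- Compound 1 `COc1ccc(-c2nc3cc([N+](=O)[O-])ccc3[nH]2)c(OC)c1OC`: > 100000 nM
- Compound 2 `O=[N+]([O-])c1ccc(-c2nc3cc(Cl)c(Cl)cc3[nH]2)cc1`: 17000 nM

Compound 1 stands at > 100000 nM, which is a limit of the assay and not a number. Among the measured compounds shown here, compound 2, at 17000 nM, holds the only true number so far, so it has no measured neighbour to be ranked against.

Compound 3 `Nc1ccc(-c2nc3cc(Cl)c(Cl)cc3[nH]2)cc1` keeps the core of compound 2 and changes one group, with amino in place of nitro on an aromatic carbon. For the measured compounds named here, no measured pair shows this change on its own, so its size in this assay can only be judged loosely. A small move toward lower toxicity is expected, roughly the size of the usual scatter, starting from compound 2 at 17000 nM. The expected size is a 1.8-fold higher number from compound 2 to compound 3 (0.25 log units; within the scatter). For compound 3 the estimated value is 30000 nM, with an expected range of 8000 nM to 100000 nM.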

Compound 3, half-maximal cytotoxic concentration: 17000 nM
Beside the measured number, compound 3's estimate is 1.8-fold (0.25 log units) above it; the measured number falls inside the stated range.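

In this assay, amino in place of nitro, on an aromatic carbon para to a large group, gives no change at the digits printed from compound 2 to compound 3 (within the scatter). Among the compounds shown here, this is the first comparison in the set between compounds that differ in one place only. It shows that, at this position, a nitro group can give way to an amino group, which brings in a hydrogen-bond donor, without the number moving beyond the scatter, so neither compound can be called the more toxic in this test.

On these data alone, whether other groups at this position, such as a carboxylic acid or an acetamide, would leave the number just as still remains open. Compound 1 differs from these two in more than one place and offers no direct comparison, and its value is only a limit: the limit of > 100000 nM in this assay, at which 1 of the 3 values shown sits.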